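The source may hold more compounds than are shown below. What is called first, only, known or untested is meant among the compounds shown, and "the series" means these compounds.

Compound 1 `COc1ccc(C(=O)/C=C/c2cn(-c3ccccc3)nc2-c2ccsc2)c(OC)c1` gives 3000 nM in a functional assay on Huh-7 cells (Homo sapiens) for inhibition, read by sulforhodamine B assay, with a stated time of 72 h; a higher number here means a weaker inhibitor, a lower number a stronger inhibitor. Compound 2 `COc1ccc(C(=O)/C=C/c2cn(-c3ccccc3)nc2-c2ccncc2)c(OC)c1OC` gives 3700 nM in this assay, and the numbers of compound 2 and compound 1 lie within the scatter of each other, so neither stands apart. Compound 3 `COc1ccc(C(=O)/C=C/c2cn(-c3ccccc3)nc2-c2ccncc2)c(OC)c1` differs from compound 2 by hydrogen in place of methoxy on an aromatic carbon. Going by the values given here, no pair of measured compounds shows the effect of such a change, so compound 3 is expected to stay close to compound 2, with a step of a 1.1-fold lower number from compound 2 to compound 3 (0.02 log units; within the scatter) that is not expected to exceed the scatter. Compound 3 is therefore estimated at 3500 nM, between 1500 nM and 8000 nM.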

Compound 3, half-maximal inhibitory concentration: 4400 nM
Compound 3: middle estimate off by 1.3-fold (0.10 log units), on the low side, and the stated range covers the measured number.
By their numbers in this assay, from the lowest: compounds 1, 2 and 3 (each within the scatter of the next).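

Hydrogen in place of methoxy on an aromatic carbon, ortho to two methoxy groups, gives a 1.2-fold higher number from compound 2 to compound 3 (0.08 log units; within the scatter) in this assay, so in this series that methoxy can go without a change beyond the scatter. Pyridin-4-yl in place of thiophen-3-yl on an aromatic carbon gives a 1.5-fold higher number from compound 1 to compound 3 (0.17 log units; within the scatter), a single-place reading that compounds 1 and 2, which differ in two places, could not give. Nothing at hand bears on why these steps stay small.

Going by these compounds, it remains open whether an amine or a carboxylic acid at this position would move the number beyond the scatter. Also open, on these data alone, is what the two remaining methoxy groups contribute.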